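A few compounds are considered here, and "the series" means these few. Any claim that something is new, unique, unknown or untested is made for them only; others in the source may bear on it.

Of the compounds shown here, two have been tested so far in a functional assay on HeLa cells (Homo sapiens) for cytotoxicity, read by MTT assay, with a stated time of 24 h; a higher number here means a weaker inhibitor, a lower number a stronger inhibitor. In this assay, compound 1 (`CCCCCCCCCCCCCC(=O)Nc1nnc(S[C@@H]2O[C@H](COC(C)=O)[C@H](OC(C)=O)[C@H](OC(C)=O)[C@H]2OC(C)=O)s1`) gives 61300 nM, and compound 2 (`CCCCCCCC(=O)Nc1nnc(S[C@@H]2O[C@H](CO)[C@H](O)[C@H](O)[C@H]2O)s1`) gives 50800 nM. These two numbers lie within the usual scatter of repeated measurements, which leaves compound 2 level with compound 1, and neither can be ranked above the other.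

The next compound to consider is compound 3 (`CCCCCCCCCCCCCC(=O)Nc1nnc(S[C@@H]2O[C@H](CO)[C@H](O)[C@H](O)[C@H]2O)s1`). It is compound 2 with a single change: hexyl in place of hydrogen on a saturated chain carbon, seven bonds along the chain from a carbonyl carbon.

For the measured compounds named here, no measured pair of compounds shows this change on its own, which makes any forecast uncertain. In this assay, a modest step towards a lower number is expected, meaning a somewhat stronger inhibitor, though it may not clear the scatter by much. The expected change is a 1.7-fold lower number from compound 2 to compound 3 (0.23 log units; within the scatter). For compound 3 the estimated value is 30000 nM, with an expected range from 10000 nM to 80000 nM.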

Compound 3, half-maximal inhibitory concentration: 31000 nM
Estimate against measurement, compound 3: 1.0-fold (0.01 log units) below; measured number inside the range.
By their numbers in this assay, from the lowest: compounds 3, 2 and 1 (each within the scatter of the next).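

For the compounds shown here, compounds 2 and 3 are the first pair here that differ in one place only, so hexyl in place of hydrogen on a saturated chain carbon, seven bonds along the chain from a carbonyl carbon, can now be read on its own. The step in this assay is a 1.6-fold lower number from compound 2 to compound 3 (0.21 log units; within the scatter) and so leaves the two compounds level: this single pair shows that the position accepts a hexyl group without a clear shift in the number, and it gives no firm sign that the added chain matters in this assay. No measurement offered here explains this result, whatever its size.

Going by these compounds alone, it remains open whether a longer chain than the one in compound 3 would give a step beyond the scatter, and what an amine or a carboxylic acid in place of the hexyl group would do. On these data alone, it is also open whether the same change would give a similar step in compounds that carry the acetyl groups seen in compound 1.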